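The compounds below may be only part of what the source reports. "The series", "measured", "known", "first", "only" and "open" are said of these compounds alone.

Series notes. Compound 1 `N#CCNC(=O)[C@@H]1C[C@@H](S(=O)(=O)CC2CC2)C[C@H]1C(=O)N1CCOCC1` gives, in an assay on isolated protein for inhibition of cathepsin S (Homo sapiens), read by fluorescence, with a stated time of 20 min (on this read-out higher numbers stand for weaker inhibition and lower numbers for stronger inhibition), a value of 230 nM. Compound 2 `N#CC1(NC(=O)[C@@H]2C[C@@H](S(=O)(=O)c3ccccc3)C[C@H]2C(=O)N2CCCCC2)CC1` gives, in this assay, 0.8 nM, the lowest of the two numbers measured, and the gap to compound 1 lies beyond the scatter. Compound 3 `N#CC1(NC(=O)[C@@H]2C[C@@H](S(=O)(=O)c3ccccc3)C[C@H]2C(=O)N2CCNCC2)CC1` has not yet been measured; it differs from compound 2 by piperazin-1-yl in place of piperidin-1-yl on a carbonyl carbon. Among the measured compounds shown here, no measured step of this kind exists, so the expected step from compound 2 to compound 3 is estimated as small, a 1.9-fold higher number from compound 2 to compound 3 (0.27 log units; within the scatter), if anything a mild weakening, possibly within the scatter. Compound 3 is accordingly expected to give about 1.5 nM, with a range of 0.4 nM to 6 nM.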

Compound 3, half-maximal inhibitory concentration: 11 nM
Compound 3: the middle estimate sits 7.3-fold (0.87 log units) below what was measured; measured number above the stated range.
By their numbers in this assay, from the lowest: compound 2; then compound 3; then compound 1.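

In this assay, this position on a carbonyl carbon proves sensitive to the ring placed there: piperazin-1-yl in place of piperidin-1-yl gives a 14-fold higher number from compound 2 to compound 3 (1.14 log units; beyond the scatter) and so weakens inhibition, although the ring size stays the same. Among the compounds shown here, this is the first one-place step, and it shows that swapping one ring carbon for a nitrogen is enough to shift the number beyond the scatter. Nothing at hand accounts for this loss.

Still open, from the compounds shown here alone, is whether 4-methylpiperazin-1-yl on the same carbonyl carbon would stay close to compound 3 or return towards compound 2. A single step also cannot show whether the change keeps its size on other cores.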